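A few compounds are considered here, and "the series" means these few. Any claim that something is new, unique, unknown or untested is made for them only; others in the source may bear on it.

Measured so far:
- compound 1 `CN1C(=O)NC2(CC2(C)C)C1=O`: 40%
- compound 2 `CCCCN1C(=O)NC2(CC2(C)C)C1=O`: 20%

In a functional assay on the whole organism for inhibition, with Mus musculus as the target, in the maximal electroshock model, at a dose of 7.5 mg/kg by the oral route (on this read-out lower numbers stand for a weaker effect and higher numbers for a stronger effect at the one dose given), compound 1 gives 40%, and compound 2 gives 20%. For the measured compounds named here, the only measured step is a number 20 percentage points lower from compound 1 to compound 2 (beyond the scatter), a modest fall beyond the scatter. Compound 2 therefore stands lowest of the two numbers, with compound 1 as its nearest neighbour and higher beyond the scatter.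

Compound 3 `CCC(CO)N1C(=O)NC2(CC2(C)C)C1=O` is the next member of the series. Its change from compound 2 is 1-(hydroxymethyl)propyl in place of butyl on an amide-type nitrogen in a ring. Going by the values given here, the measured step bears on it only in part: it shows that building out the group on this ring nitrogen, from hydrogen to butyl, cost inhibition, but no measured pair covers a hydroxymethyl group or any hydrogen-bond donor at this place. The chain length is kept; what is new is the hydroxyl and a branch. Given that the one relevant step was modest, the expected step of a number 10 percentage points higher from compound 2 to compound 3 (within the scatter) is small, with no firm direction beyond the scatter. Compound 3 is expected to give about 30%, within 10% to 55%.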

Compound 3, a percentage reported as inhibition, in the whole organism at one dose (the size of the read-out at that dose, not a potency): 30%
For compound 3 middle estimate and measured number coincide at the digits printed, and the stated range covers the measured number.
By their numbers in this assay, from the lowest: compounds 2, 3 and 1 (each within the scatter of the next, the first and the last beyond it).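

For the compounds shown here, at the amide-type nitrogen in a ring, 1-(hydroxymethyl)propyl is the first group to carry a hydrogen-bond donor and acceptor, and in this assay its exchange for butyl gives a number 10 percentage points higher from compound 2 to compound 3 (within the scatter), so the hydroxyl and branch together cannot be told apart from the unbranched chain at this dose. Against the small group, the exchange gives a number 10 percentage points lower from compound 1 to compound 3 (within the scatter), which leaves compound 3 inseparable from both neighbours even though the step between those two, a number 20 percentage points lower from compound 1 to compound 2 (beyond the scatter), lies beyond the scatter; at this position the series therefore reads as a span of overlapping values rather than a clean order. Nothing available explains the result or ties it to either the hydroxyl or the branch.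

The compounds shown leave open which of the two new features matters, a question that a 1-methylpropyl group, with the branch alone, and a straight 4-hydroxybutyl chain, with the hydroxyl alone, would separate. Also open, going by these compounds, is how an amine or a carboxylic acid on the same chain would read, and whether any of these differences would hold beyond the single oral dose.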